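Acetyl in place of thiazolylcarbonyl on the shared core

This account rests on a few compounds, and the source may have more. Where it says the series, first, only, none or still open, it means among the compounds named here.

Working notes. The three measured compounds share one core and differ in the group on the carbonyl carbon. Compound 1 `O=C(c1cscn1)N1CCC(C(=O)N2N=CC[C@H]2c2ccccc2)CC1` reaches only a limit in an ADME assay on microsomes (Homo sapiens) for metabolic stability (on this read-out lower numbers stand for a shorter-lived compound and higher numbers for a longer-lived compound), reported as > 3 h. Compound 2 `O=C(C1CCN(C(=O)C(F)(F)F)CC1)N1N=CCC1c1ccccc1` likewise gives a limit in this assay, > 1.5 h. Compound 3 `O=C(C1CCOCC1)N1N=CCC1c1ccccc1` also gives a limit in this assay, > 1.5 h. Every value shown is thus a limit, two sitting at the limit of > 1.5 h in this assay, at which 2 of the 3 values shown sit, and one at the limit of > 3 h in this assay, at which 1 of the 3 values shown sits, so no order among compounds 1, 2 and 3 can be drawn. Compound 4 `CC(=O)N1CCC(C(=O)N2N=CC[C@H]2c2ccccc2)CC1` differs from compound 1 by methyl in place of 1,3-thiazol-4-yl on a carbonyl carbon. For the measured compounds named here, no step between measured compounds exists; the change is expected to stay within scatter in this assay. Compound 4 is expected at 3 h, between 1.5 h and 6 h. The step of a number no higher from compound 1 to compound 4 (the limit leaves the size open) is expected to be negligible.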

Compound 4, half-life: > 2.75 h
Compound 4: no number, only a limit (the forecaster's own chance of this, stated with the estimate: 50%); the middle value does not contradict the limit.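

In this assay compound 1 gives only a limit, > 3 h. For the compounds shown here, compound 4 also gives only a limit, > 2.75 h, so no step from compound 1 to compound 4 can be read. The compounds shown leave open whether methyl in place of 1,3-thiazol-4-yl changes the half-life at all.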